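From methyl to 4-chlorophenyl on a ring nitrogen

The source may report more compounds than this note shows. Statements on the series, on what has been measured and on what is new or still open speak of the compounds shown alone.

Compound 1 `O=C1NCN(c2ccccc2)C12CCN(CCCCC(c1ccc(F)cc1)c1ccc(F)cc1)CC2`: 4700 nM
Compound 2 `CN1CCN(CCCC(c2ccc(F)cc2)c2ccc(F)cc2)CC1`: > 50000 nM

Both compounds were tested in a functional assay on H4 cells (Homo sapiens) for activation, read by fluorescence and microscopy, with a stated time of 4 h; a lower number here means that less compound is needed, a higher number that more compound is needed for the effect. Compound 1 gives a true number there, 4700 nM. Compound 2 stands only at a limit of the assay, > 50000 nM, as the limit of > 50000 nM in this assay, at which 1 of the 2 values shown sits, shows.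

Compound 3 `Fc1ccc(C(CCCN2CCN(c3ccc(Cl)cc3)CC2)c2ccc(F)cc2)cc1` carries 4-chlorophenyl in place of methyl on an amine nitrogen in a ring. In this assay, going by the values given here, a clear step toward less compound is expected, with compound 1 at 4700 nM as the only numerical guide. The expected step is an at least 5.5-fold lower number from compound 2 to compound 3 (0.74 log units; beyond the scatter). Compound 3 is estimated at 9000 nM (2500 nM to 35000 nM) .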

Compound 3, half-maximal effective concentration: > 50000 nM
Compound 3 was reported as a limit; the forecaster's own chance of this, stated with the estimate: 25%; middle value at least 5.5-fold (0.74 log units) from the limit.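

Compound 2 and compound 3 both stand only at a limit in this assay, so no step between them can be read: the limit of > 50000 nM in this assay, at which 2 of the 3 values shown sit.

Going by these compounds, whether 4-chlorophenyl in place of methyl on an amine nitrogen in a ring changes the amount of compound needed remains open.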